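Swapping an aryl for a benzyl on the shared core

A few compounds are considered here, and "the series" means these few. Any claim that something is new, unique, unknown or untested is made for them only; others in the source may bear on it.

Compound 1 `Fc1ccc(-c2ccc3c(NCCCNCc4ccco4)ccnc3c2)cc1` was tested in an ADME assay for permeability, using PAMPA, with a stated time of 30 min, at pH 7.4 (on this read-out higher numbers stand for higher permeability and lower numbers for lower permeability), where compound 1 gives 237 10^-6 cm/s. Compound 2 `COc1ccc(F)cc1CNCCCNc1ccnc2cc(-c3ccc(F)cc3)ccc12` gives 237 10^-6 cm/s in this assay, and compound 3 `COc1cccc(CNCCCNc2ccnc3cc(Oc4cccc(N(C)C)c4)ccc23)c1O` gives 317 10^-6 cm/s. On these numbers compound 1 stands level with compound 2, and compound 3 lies within the scatter of both. Among the measured compounds shown here, the one measured step, no change at the digits printed from compound 1 to compound 2 (within the scatter), concerns the group on the saturated chain carbon bound to an amine nitrogen and not the position now in question.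

Compound 4 `Fc1ccc(Cc2ccc3c(NCCCNCc4ccco4)ccnc3c2)c(Cl)c1` differs from compound 1 by 2-chloro-4-fluorobenzyl in place of 4-fluorophenyl on an aromatic carbon, a 2-chloro-4-fluorobenzyl entering where a 4-fluorophenyl leaves. For the measured compounds named here, no measured step touches this part of the shared core, and the single measured change elsewhere in the molecule left the number unchanged. In this assay the expected step is therefore a 1.1-fold higher number from compound 1 to compound 4 (0.02 log units; within the scatter), nothing beyond the scatter. Compound 4 is thus estimated at 250 10^-6 cm/s, with a range from 140 10^-6 cm/s to 420 10^-6 cm/s.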

Compound 4, apparent permeability: 23 10^-6 cm/s
Estimate against measurement, compound 4: 11-fold (1.04 log units) above; the measured number lies below the stated range.
By their numbers in this assay, from the lowest: compound 4; then compounds 1, 2 and 3 (each within the scatter of the next).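

In this assay this aromatic carbon of the shared core proves sensitive to the group it carries: 2-chloro-4-fluorobenzyl in place of 4-fluorophenyl gives a 10-fold lower number from compound 1 to compound 4 (1.01 log units; beyond the scatter) and takes the read-out well beyond the scatter. The earlier compounds shown here offered only no change at the digits printed from compound 1 to compound 2 (within the scatter) for a change in the group on the saturated chain carbon, so they gave no sign that the number could move this far. The swap brings in a chlorine and one more carbon together, so the step belongs to the pair and cannot be shared out between them.

As far as these compounds go, whether the step follows the chlorine or the added carbon stays open, and a plain benzyl, a 4-fluorobenzyl or a 2-chloro-4-fluorophenyl group on this carbon would tell these apart. Nothing at hand gives a reason for the step either.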